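The source may report more compounds than this note shows. Statements on the series, on what has been measured and on what is new or still open speak of the compounds shown alone.

Compound 2 `COC(=O)c1cncc(NS(=O)(=O)c2cc(Cl)ccc2OC)c1` and compound 1 `COc1ccc(Cl)cc1S(=O)(=O)Nc1cncc(-c2ccncc2)c1` share one core and differ only in one group on an aromatic carbon. In an assay on isolated protein for inhibition of alkaline phosphatase, tissue-nonspecific isozyme (Homo sapiens) (a lower number here means a stronger inhibitor, a higher number a weaker inhibitor), compound 1 gives 73 nM, and compound 2 gives 65 nM; the step of a 1.1-fold lower number from compound 1 to compound 2 (0.05 log units; within the scatter) shows the two sitting within the scatter of each other. Compound 3 `COc1ccc(Cl)cc1S(=O)(=O)Nc1cncc(C(=O)N2CCN(C)CC2)c1` carries 4-methylpiperazin-1-yl in place of methoxy on a carbonyl carbon. Among the measured compounds shown here, no measured step covers this exact change; the only guide is that the one swap at that aromatic carbon, from compound 1 to compound 2, moved the number little. A modest step of a 1.7-fold higher number from compound 2 to compound 3 (0.23 log units; within the scatter) toward a weaker inhibitor is therefore expected, and compound 3 is estimated at 110 nM, within 30 nM to 400 nM.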

Compound 3, half-maximal inhibitory concentration: 671 nM
Compound 3: the middle estimate sits 6.1-fold (0.79 log units) below what was measured, and the stated range ends below it.
By their numbers in this assay, from the lowest: compounds 2 and 1 (each within the scatter of the next); then compound 3.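

Until now, swapping the group on this aromatic carbon had changed little, but this position is clearly not indifferent to every group: in this assay there is a 10-fold higher number from compound 2 to compound 3 (1.01 log units; beyond the scatter) when 4-methylpiperazin-1-yl replaces methoxy on the carbonyl carbon. Measured against the pyridin-4-yl compound, the result is the same, with a 9.2-fold higher number from compound 1 to compound 3 (0.96 log units; beyond the scatter), so (4-methylpiperazin-1-yl)carbonyl gives the weaker inhibitor in both comparisons. No available measurement explains this loss.

As far as these compounds go, it remains open whether a dimethylamide or a carboxylic acid on this aromatic carbon would stay close to compound 2 or fall toward compound 3.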